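From Fluoro to Chloro on a Fused Ring

The source may report more compounds than this note shows. Statements on the series, on what has been measured and on what is new or still open speak of the compounds shown alone.

Measured compounds:
compound 1, `c1ccc2c(c1)CCCCC2CCN1CCN(c2cccc3c2OCCO3)CC1`, gives 4.26 mg/kg
compound 2, `Fc1cccc2c1CC2CN1CCN(c2cccc3c2OCCO3)CC1`, gives 2.51 mg/kg
compound 3, `c1ccc2c(c1)CCC2CN1CCN(c2cccc3c2OCCO3)CC1`, gives 1.32 mg/kg

In a functional assay on the whole organism for antagonist activity, with Rattus norvegicus as the target (on this read-out lower numbers stand for an effect already at smaller amounts and higher numbers for an effect only at larger amounts of compound), compound 2 holds the second highest of the three numbers. Its nearest neighbour is compound 1 and its furthest is compound 3, yet both gaps lie within the usual scatter, so no order among the three can be read from these values.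

Compound 4, `Clc1cccc2c1CC2CN1CCN(c2cccc3c2OCCO3)CC1`, has not been measured. It differs from compound 2 in one place: chloro in place of fluoro on an aromatic carbon. Among the compounds with values here, no pair of measured compounds shows what such an exchange does here, so nothing in the data fixes the size of the step. The expectation is no step beyond the scatter, so the step from compound 2 to compound 4 is expected to be a 1.0-fold lower number from compound 2 to compound 4 (0.00 log units; within the scatter). Compound 4 is therefore expected to give 2.5 mg/kg, estimated between 1 mg/kg and 6 mg/kg.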

Compound 4, dose for 50% inhibition: 0.8 mg/kg
Estimate against measurement, compound 4: 3.1-fold (0.49 log units) above, outside the stated range (below it).
By their numbers in this assay, from the lowest: compounds 4, 3, 2 and 1 (each within the scatter of the next, the first and the last beyond it).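

In this assay chloro in place of fluoro on this aromatic carbon gives a 3.1-fold lower number from compound 2 to compound 4 (0.50 log units; beyond the scatter) and so moves the number beyond the usual scatter. The earlier compounds shown here could not show this: the choice between these two halogens at this place, ortho to a fused ring, can alone change the dose needed. Nothing measured here accounts for the step. The compounds shown leave open what bromo, methoxy or an amine on the same carbon would do, and whether chloro would give a similar step on another carbon of this ring.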